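The compounds below may be only part of what the source reports. "The series", "measured", "known", "first", "only" and "open" are said of these compounds alone.

Compound 1 `CCN(c1ccncc1)n1cccc1` and compound 2 `CCCCN(c1ccncc1)n1cccc1` share one core, while compound 3 `CN(c1ccncc1)n1ccc(C=O)c1` is built on another; the difference between the two cores is not broken down here. Compound 2 differs from compound 1 by ethyl in place of hydrogen on a saturated chain carbon, two bonds along the chain from a nitrogen on an aromatic ring. In a functional assay on the whole organism with Mus musculus as the target (a lower number here means that less compound is needed, a higher number that more compound is needed for the effect), compound 1 gives only a limit of the assay, > 20 mg/kg. Compound 2 likewise gives only a limit, > 20 mg/kg. The step that the two limits leave unreadable from compound 1 to compound 2 therefore has no readable size. Compound 3 also gives only a limit in this assay, > 20 mg/kg. Every measured value thus sits at the limit of > 20 mg/kg in this assay, at which 3 of the 3 values shown sit.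

Compound 4 `CCCN(c1ccncc1)n1ccc(C=O)c1` has not yet been measured. It differs from compound 3 by ethyl in place of hydrogen on a saturated chain carbon bound to a nitrogen on an aromatic ring. This is the same kind of change as that from compound 1 to compound 2, but not the same: there the place was two bonds along the chain from a nitrogen on an aromatic ring, here it is bound to a nitrogen on an aromatic ring. The step from compound 3 to compound 4 is expected to be about a step that the limit leaves unreadable from compound 3 to compound 4, because every measured value sits at the limit of > 20 mg/kg in this assay, at which 3 of the 3 values shown sit, and no readable step points elsewhere. Compound 4 is therefore expected to give roughly 30 mg/kg in this assay, within 8 mg/kg to 120 mg/kg, most probably again only as a limit.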

Compound 4, dose for half-maximal effect: > 20 mg/kg
Compound 4: no number, only a limit; the forecaster's own chance of this, stated with the estimate: 75%; the middle value does not contradict the limit.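

In this assay compound 4 gives > 20 mg/kg as a limit and not a number, so no new step can be read between compound 3 and compound 4. The compounds shown leave open what dose any of them needs for the effect and whether changing the chain matters, because all the results stop at one value: the limit of > 20 mg/kg in this assay, at which 4 of the 4 values shown sit.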